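Nitro for methoxy in an antiproliferative oxadiazole pair

A few compounds are considered here, and "the series" means these few. Any claim that something is new, unique, unknown or untested is made for them only; others in the source may bear on it.

Measured in a functional assay on HepG2 cells (Homo sapiens) for antiproliferative activity, read by MTT assay, with a stated time of 24 h; a higher number here means a weaker inhibitor, a lower number a stronger inhibitor:
Compound 1 `COc1ccc(Cc2nnc(Cn3nnc4ccccc43)o2)cc1` gives 357000 nM.
Compound 2 `O=[N+]([O-])c1ccc(Cc2nnc(Cn3nnc4ccccc43)o2)cc1` gives 367000 nM.
Compound 3 `COc1ccc(-c2nnc(Cn3nnc4ccccc43)o2)cc1` gives 477000 nM.

Compound 1 and compound 2 share a core and differ by nitro in place of methoxy on an aromatic carbon. This change made a 1.0-fold higher number from compound 1 to compound 2 (0.01 log units; within the scatter). Compound 3 carries a different core; the difference between the core of compound 1 and the core of compound 3 is not broken down here. The numbers of compound 3, compound 2 and compound 1 in this assay all lie within the usual scatter of one another, so no order among the three can be read from them.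

Compound 4 `O=[N+]([O-])c1ccc(-c2nnc(Cn3nnc4ccccc43)o2)cc1` is not yet measured. It differs from compound 3 by nitro in place of methoxy on an aromatic carbon. Within the data shown here, the surroundings of the change are described in the same words for both pairs, so this is the same change as the one from compound 1 to compound 2. For compound 4 in this assay the step of a 1.0-fold higher number from compound 3 to compound 4 (0.00 log units; within the scatter) is expected, resting on the step of a 1.0-fold higher number from compound 1 to compound 2 (0.01 log units; within the scatter), which stayed within the scatter. Compound 4 is therefore estimated at 480000 nM, with a range from 300000 nM to 760000 nM.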

Compound 4, half-maximal inhibitory concentration: 483000 nM
Beside the measured number, compound 4's estimate is 1.0-fold (0.00 log units) below it, and the stated range covers the measured number.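

In this assay, nitro in place of methoxy gives a 1.0-fold higher number from compound 3 to compound 4 (0.01 log units; within the scatter), so on the core of compound 3 this change again leaves the number within the scatter. Set beside the earlier pair, the two steps do not differ: the same change on two cores in this assay, a 1.0-fold higher number (0.01 log units; within the scatter) from compound 1 to compound 2 and a 1.0-fold higher number (0.01 log units; within the scatter) from compound 3 to compound 4, 1.0-fold (0.01 log units) apart, within the scatter of two such steps

The change therefore carries from one core to the other in this limited sense, but a step within the scatter on both cores is a poor test of transfer: it does not show that a larger effect would carry over, it gives no cause, and it covers these two cores only.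

Only methoxy and nitro are shown at this place on the six-membered aromatic ring, so it remains open whether an amine or a carboxylic acid there would move the number beyond the scatter. Also open, as far as these compounds go, is whether a longer chain, in the part of the core that differs between compound 1 and compound 3, would change the picture.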